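The source may report more compounds than this note shows. Statements on the series, on what has been measured and on what is new or still open speak of the compounds shown alone.

Measured so far in an ADME assay on Caco-2 cells (Homo sapiens) for permeability, read by LC-MS, with a stated time of 2 h, tested at 3 uM; a higher number here means that the compound crosses the layer faster, a lower number that the compound crosses the layer more slowly:
- compound 1 `CCN(C(=O)OC)c1cc2oc(-c3ccc(F)cc3)c(C(=O)NC)c2cc1-c1ccc(OC)c(C(=O)NC2(c3ncccn3)CC2)c1` gives 232 nm/s
- compound 2 `CCN(C(C)=O)c1cc2oc(-c3ccc(F)cc3)c(C(=O)NC)c2cc1-c1ccc(OC)c(C(=O)NC2(c3ncccn3)CC2)c1` gives 308 nm/s

Compound 2 sits alongside compound 1: the step of a 1.3-fold higher number from compound 1 to compound 2 (0.12 log units; within the scatter) is within the scatter, so nothing separates the two on the numbers shown.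

Compound 3 `CCN(C(=O)C(F)(F)F)c1cc2oc(-c3ccc(F)cc3)c(C(=O)NC)c2cc1-c1ccc(OC)c(C(=O)NC2(c3ncccn3)CC2)c1` differs from compound 2 by trifluoromethyl in place of methyl on a carbonyl carbon. Among the measured compounds shown here, no measured step bears directly on this exchange. For the measured compounds named here, the one step available, a 1.3-fold higher number from compound 1 to compound 2 (0.12 log units; within the scatter), alters the same carbonyl carbon and stays within the scatter, which gives no basis for expecting a shift beyond the scatter in this assay here either. Compound 3 is therefore expected to land close to compound 2, with the step of a 1.1-fold higher number from compound 2 to compound 3 (0.03 log units; within the scatter) taken as no larger than the scatter. The estimate for compound 3 is 330 nm/s, with a range from 180 nm/s to 600 nm/s.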

Compound 3, apparent permeability: 115 nm/s
Compound 3: the middle estimate sits 2.9-fold (0.46 log units) above what was measured; measured number below the stated range.
By their numbers in this assay, from the lowest: compounds 3, 1 and 2 (each within the scatter of the next, the first and the last beyond it).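

In this assay, among the compounds shown here, the carbonyl carbon on the amide-type nitrogen proves sensitive to what it carries: trifluoromethyl in place of methyl gives a 2.7-fold lower number from compound 2 to compound 3 (0.43 log units; beyond the scatter) and is the only step at this place that lies beyond the scatter. Trifluoromethyl in place of methoxy gives a 2.0-fold lower number from compound 1 to compound 3 (0.30 log units; within the scatter) and stays within it, so compound 3 separates from compound 2 but not from compound 1. Nothing available on these compounds accounts for the step from methyl to trifluoromethyl.

Only methoxy, methyl and trifluoromethyl are shown on this carbonyl carbon, so it remains open whether the lower number needs all three fluorine atoms or would also appear with difluoromethyl. As far as these compounds go, an amine or a longer chain such as propyl at the same place is also open.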